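A few compounds are considered here, and "the series" means these few. Any claim that something is new, unique, unknown or untested is made for them only; others in the source may bear on it.

In a functional assay on SK-BR-3 cells (Homo sapiens) for antiproliferative activity (a higher number here means a weaker inhibitor, a lower number a stronger inhibitor), compound 1 `CC(C)=CCc1cc(C(=O)Nc2cc3ccc(OCCC4CCCCN4)c(C)c3oc2=O)ccc1O` gives 640 nM and compound 3 `CC(C)=CCc1cc(C(=O)Nc2cc3ccc(OCCCN4CCCC4)c(C)c3oc2=O)ccc1O` gives 720 nM, so the two sit level. Compound 2 `CC(C)=CCc1cc(C(=O)Nc2cc3ccc(OCCCN4CCCCC4)c(C)c3oc2=O)ccc1O` gives no number, only a limit of the assay, > 50000 nM. Among the measured compounds shown here, compound 3 therefore stands alongside compound 1, the only other compound here with a true number.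

Compound 4 `CCNCCCOc1ccc2cc(NC(=O)c3ccc(O)c(CC=C(C)C)c3)c(=O)oc2c1C` keeps the shared core and changes only the amine end of the chain, where 3-(ethylamino)propyl replaces 3-(pyrrolidin-1-yl)propyl: ethylamino in place of pyrrolidin-1-yl on a saturated chain carbon, three bonds along the chain from an oxygen on an aromatic ring. For the measured compounds named here, no measured step swaps pyrrolidin-1-yl for ethylamino, so the evidence is indirect. Two measured changes at this end of the chain gave very different results. One was small, a 1.1-fold higher number from compound 1 to compound 3 (0.05 log units; within the scatter). The other was large, an at least 69-fold lower number from compound 2 to compound 3 (1.84 log units; beyond the scatter), and the step of an at least 78-fold higher number from compound 1 to compound 2 (1.89 log units; beyond the scatter) was of similar size. A change here can therefore leave this assay almost untouched or can remove measurable activity, and these three compounds do not show which outcome to expect.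

The central expectation rests on compound 3 at 720 nM and on the small step of a 1.1-fold higher number from compound 1 to compound 3 (0.05 log units; within the scatter). The expected step is a 1.4-fold higher number from compound 3 to compound 4 (0.14 log units; within the scatter), which means no clear change beyond the scatter, although the large steps keep the upper end of the range wide. Compound 4 is estimated at 1000 nM, with an expected range of 300 nM to 6000 nM.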

Compound 4, half-maximal inhibitory concentration: 720 nM
For compound 4 the middle estimate is 1.4-fold (0.14 log units) above the measured one; the range from low to high includes it.
By their numbers in this assay, from the lowest: compounds 1, 3 and 4 (each within the scatter of the next). At a limit, above all of these: compound 2.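

In this assay, ethylamino in place of pyrrolidin-1-yl removes the ring and brings in a hydrogen-bond donor, yet the number holds: no change at the digits printed from compound 3 to compound 4 (within the scatter). Compound 4 also sits level with compound 1, which carries piperidin-2-yl on a shorter chain: a 1.1-fold higher number from compound 1 to compound 4 (0.05 log units; within the scatter). So among compounds 1, 3 and 4, a ring at the amine end is not needed to keep activity at this level, whereas compound 2, with its piperidin-1-yl, goes against any reading that all these amine ends behave alike, as the open-chain ethylamino shows in an at least 69-fold lower number from compound 2 to compound 4 (1.84 log units; beyond the scatter), a step that rests on a limit and not on a true number for compound 2: the limit of > 50000 nM in this assay, at which 1 of the 4 values shown sits.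

The compounds shown leave open why piperidin-1-yl alone stands apart when pyrrolidin-1-yl and ethylamino sit level, and no cause can be read from these values. They also do not say how far the open-chain result extends, for example to a dimethylamino group, an unsubstituted amine, a morpholin-4-yl ring or a longer chain between the oxygen and the amine.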